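A few compounds are considered here, and "the series" means these few. Any claim that something is new, unique, unknown or untested is made for them only; others in the source may bear on it.

Measured so far in a functional assay on CCRF-CEM cells (Homo sapiens); on this read-out higher numbers stand for lower toxicity in this test and lower numbers for higher toxicity in this test:
Compound 1 `COC(=O)Cn1c(=O)c(C)cn([C@@H]2O[C@H](CO[Si](C)(C)C(C)(C)C)[C@@]3(OS(=O)(=O)C=C3N)[C@H]2O[Si](C)(C)C(C)(C)C)c1=O` reaches only the assay limit, > 152000 nM.
Compound 2 `Cc1cn([C@@H]2O[C@H](CO[Si](C)(C)C(C)(C)C)[C@@]3(OS(=O)(=O)C=C3N)[C@H]2O[Si](C)(C)C(C)(C)C)c(=O)n(CC(=O)O)c1=O` gives 152000 nM.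
Compound 3 `Cc1cn([C@@H]2O[C@H](CO[Si](C)(C)C(C)(C)C)[C@@]3(OS(=O)(=O)C=C3N)[C@H]2O[Si](C)(C)C(C)(C)C)c(=O)n(CCCCO)c1=O` gives 20500 nM.

Compound 1 thus stands at the top of the series, known only as a limit, described by the limit of > 152000 nM in this assay, at which 1 of the 3 values shown sits. Compound 4 `Cc1cn([C@@H]2O[C@H](CO[Si](C)(C)C(C)(C)C)[C@@]3(OS(=O)(=O)C=C3N)[C@H]2O[Si](C)(C)C(C)(C)C)c(=O)n(CCCN(CC(=O)O)CC(=O)O)c1=O` differs from compound 1 as follows: 2-(bis(carboxymethyl)amino)ethyl in place of methoxycarbonyl on a saturated chain carbon bound to an aromatic nitrogen. Measured steps at the same position are an at least 7.4-fold lower number from compound 1 to compound 3 (0.87 log units; beyond the scatter) and a 7.4-fold lower number from compound 2 to compound 3 (0.87 log units; beyond the scatter), while a number no higher from compound 1 to compound 2 (the limit leaves the size open) shows no rise in the number when the ester becomes an acid. Compound 4 carries carboxy groups, as compound 2 does, so no step beyond the scatter is expected in this assay. The expected step is an at least 1.0-fold lower number from compound 1 to compound 4 (0.03 log units; that floor lies within the scatter). Compound 4 is estimated at 140000 nM, within 45000 nM to 400000 nM.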

Compound 4, half-maximal cytotoxic concentration: > 250000 nM
Compound 4 ended at the assay's limit; the forecaster's own chance of this, stated with the estimate: 60%; middle value at least 1.7-fold (0.25 log units) from the limit.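

In this assay compound 4 reaches only a limit, > 250000 nM. Ending the chain in bis(carboxymethyl)amino rather than hydroxymethyl gives an at least 12-fold higher number from compound 3 to compound 4 (1.08 log units; beyond the scatter), so a long chain at this place does not by itself bring the number down, and the end of the chain matters. Replacing carboxy with 2-(bis(carboxymethyl)amino)ethyl gives an at least 1.6-fold higher number from compound 2 to compound 4 (0.21 log units; that floor lies within the scatter), which separates neither compound from the other, and the step joining compound 1 and compound 4 cannot be read.

Open, from the compounds shown here alone, is whether a simple tertiary amine at the chain end, without the carboxymethyl arms, keeps the number high. Also open, going by these compounds, is what a longer chain ending in a single carboxylic acid does.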